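This account rests on a few compounds, and the source may have more. Where it says the series, first, only, none or still open, it means among the compounds named here.

Measured in a functional assay on HepG2 cells (Homo sapiens), read by MTT assay, with a stated time of 48 h; a higher number here means a weaker inhibitor, a lower number a stronger inhibitor:
- compound 1 `CCn1c(C(=O)NCCCN(C)C)ccc1C(CC)(CC)c1ccc(OCC(=O)C(C)(C)C)c(C)c1`: 960 nM
- compound 2 `CCn1c(C(=O)NCCN)ccc1C(CC)(CC)c1ccc(OCC(=O)C(C)(C)C)c(C)c1`: 180 nM
- compound 3 `CCn1c(C(=O)NCCCN(C)C)ccc1C(CC)(CC)c1ccc(OCC(O)C(C)(C)C)c(C)c1`: 360 nM

Compound 3 and compound 2 lie within the usual scatter of each other. The gap to the highest number in the set is a 2.7-fold lower number from compound 1 to compound 3 (0.43 log units; beyond the scatter).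

Compound 4 `C=CCN(C)C(=O)c1ccc(C(CC)(CC)c2ccc(OCC(O)C(C)(C)C)c(C)c2)n1CC` differs from compound 3 at one place: allyl(methyl)amino in place of (3-(dimethylamino)propyl)amino on a carbonyl carbon. In words, this puts allyl(methyl)amino in place of (3-(dimethylamino)propyl)amino on a carbonyl carbon.

The step most relevant here also changes this chain, and it is modest: a 5.3-fold lower number from compound 1 to compound 2 (0.73 log units; beyond the scatter). The step from compound 1 to compound 3 concerns the 1-hydroxy-2,2-dimethylpropyl group, which compound 4 keeps, so it offers no guide to this change. Every measured compound carries an amino or dimethylamino group in this chain, while compound 4 has neither, so the direction is uncertain.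

A modest step towards a higher number in this assay is the tentative expectation, with a 1.9-fold higher number from compound 3 to compound 4 (0.29 log units; within the scatter) estimated. For compound 4 the estimated value is 700 nM, with an expected range of 170 nM to 3000 nM.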

Compound 4, half-maximal inhibitory concentration: > 50000 nM
Compound 4 was reported as a limit (the forecaster's own chance of this, stated with the estimate: 10%); middle value at least 71-fold (1.85 log units) away from the limit.
By their numbers in this assay, from the lowest: compounds 2 and 3 (each within the scatter of the next); then compound 1. At a limit, above all of these: compound 4.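

In this assay, among the compounds shown here, the group on the carbonyl carbon proves far more sensitive than the earlier compounds showed: the earlier change in this chain gave a 5.3-fold lower number from compound 1 to compound 2 (0.73 log units; beyond the scatter), whereas allyl(methyl)amino in place of (3-(dimethylamino)propyl)amino gives an at least 130-fold higher number from compound 3 to compound 4 (2.14 log units; beyond the scatter). Compound 4 is reported only as a limit: the limit of > 50000 nM in this assay, at which 1 of the 4 values shown sits. In this small set, compounds 1, 2 and 3, each with an amino or dimethylamino group in this chain, all give measured numbers, while compound 4, with neither group, does not.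

The one change removes the dimethylamino group, the amide hydrogen and the propyl chain together, so the compounds shown cannot say which loss matters. A propyl chain ending in a hydroxyl group, or an amide nitrogen carrying both methyl and 3-(dimethylamino)propyl, would help separate these parts.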